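Replacing Chloro with a Shorter Dimethylaminoalkylamino Chain

A few compounds are considered here, and "the series" means these few. Any claim that something is new, unique, unknown or untested is made for them only; others in the source may bear on it.

Three close analogues of one core have been measured in a functional assay on NCI-H1650 cells (Homo sapiens) for cytotoxicity, read by MTT assay, with a stated time of 48 h; a lower number here means a stronger inhibitor, a higher number a weaker inhibitor. Compound 1 `CCOc1ccc2c(NCCCN(C)C)ccnc2c1` gives 3830 nM, compound 2 `CCOc1ccc2c(Cl)ccnc2c1` gives 3340 nM, and compound 3 `CC(C)Oc1ccc2c(Cl)ccnc2c1` gives 2310 nM. Compound 2 stands second highest of the three numbers; its nearest neighbour is compound 1 and its furthest is compound 3, and both gaps lie within the scatter. Among the measured compounds shown here, the single step between compounds that differ in one place is a 1.4-fold lower number from compound 2 to compound 3 (0.16 log units; within the scatter), methyl in place of hydrogen on a saturated chain carbon bound to an oxygen on an aromatic ring, which does not touch the site now in question.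

Compound 4 `CCOc1ccc2c(NCCN(C)C)ccnc2c1` differs from compound 2 by (2-(dimethylamino)ethyl)amino in place of chloro on an aromatic carbon. The exchange sits on an aromatic carbon of a six-membered aromatic ring with one nitrogen, ortho to a fused ring and opposite the ring nitrogen. For the measured compounds named here, no measured step bears directly on it. Compound 1 carries a longer chain of the same kind at the same place, and its value and that of compound 2 lie within the scatter of each other. Compound 4 is therefore expected to show a 1.0-fold higher number from compound 2 to compound 4 (0.02 log units; within the scatter), a step not beyond the scatter. In this assay compound 4 is estimated at 3500 nM, within a range from 1500 nM to 8000 nM.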

Compound 4, half-maximal inhibitory concentration: 3490 nM
Compound 4: middle estimate off by 1.0-fold (0.00 log units), on the high side, within the range that was stated.
By their numbers in this assay, from the lowest: compounds 3, 2, 4 and 1 (each within the scatter of the next).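

In this assay, the exchange of chloro for (2-(dimethylamino)ethyl)amino on the aromatic carbon opposite the ring nitrogen gives a 1.0-fold higher number from compound 2 to compound 4 (0.02 log units; within the scatter), so this position now has a direct step, and a group of 6 heavy atoms with 1 hydrogen-bond donor in place of a single chlorine leaves the number within the scatter. The chain can now also be read on its own: dimethylamino in place of (dimethylamino)methyl on a saturated chain carbon, two bonds along the chain from a nitrogen on an aromatic ring, gives a 1.1-fold lower number from compound 1 to compound 4 (0.04 log units; within the scatter), so the two chains cannot be told apart in this assay. No evidence is at hand that would explain the size of either step.

The compounds shown leave open whether a different kind of group at this position, such as a primary amine, a carboxylic acid or an anilino group, or a much longer chain, would give a step beyond the scatter in this assay. They also leave open whether (2-(dimethylamino)ethyl)amino behaves the same way on the core of compound 3, which carries an isopropyl group on the oxygen.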